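Ortho Trifluoromethyl Replaces Para Nitro on the Benzamide

A few compounds are considered here, and "the series" means these few. Any claim that something is new, unique, unknown or untested is made for them only; others in the source may bear on it.

Compound 2 `CCCCCCCCCCCCn1nnc(C(NC(=O)c2ccc([N+](=O)[O-])cc2)c2ccccc2)n1` is the higher of the two numbers measured in an assay on microsomes from liver for inhibition of sterol O-acyltransferase 1 (Rattus norvegicus) (a higher number here means a weaker inhibitor, a lower number a stronger inhibitor), where compound 2 gives 540 nM. Going by the values given here, its nearest neighbour is compound 1 `CCCCCCCCCCCCn1nnc(C(NC(=O)c2ccccc2[N+](=O)[O-])c2ccccc2)n1`, which in this assay gives 240 nM, and the only measured step runs a 2.3-fold higher number from compound 1 to compound 2 (0.35 log units; beyond the scatter). Compound 3 `CCCCCCCCCCCCn1nnc(C(NC(=O)c2ccccc2C(F)(F)F)c2ccccc2)n1` is not yet measured; it differs from compound 2 by 2-(trifluoromethyl)phenyl in place of 4-nitrophenyl on a carbonyl carbon. Among the compounds with values here, the step from compound 1 to compound 2 bears on this change only in part, since it shows how moving a nitro group from the 2-position to the 4-position raised the number, but no measured pair shows a trifluoromethyl group. A return to a 2-substituted ring is therefore expected to lower the number modestly, roughly undoing the step seen from compound 1 to compound 2, with the estimated step being a 2.1-fold lower number from compound 2 to compound 3 (0.32 log units; beyond the scatter). Compound 3 is thus expected to give about 260 nM in this assay, within a range of 80 nM to 850 nM.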

Compound 3, half-maximal inhibitory concentration: 120 nM
The estimate for compound 3 lay 2.2-fold (0.34 log units) above the measured number; the range from low to high includes it.
By their numbers in this assay, from the lowest: compounds 3 and 1 (each within the scatter of the next); then compound 2.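

In this assay, replacing 4-nitrophenyl with 2-(trifluoromethyl)phenyl on the carbonyl carbon gives a 4.5-fold lower number from compound 2 to compound 3 (0.65 log units; beyond the scatter). With 2-nitrophenyl as the comparison, trifluoromethyl in place of nitro on an aromatic carbon gives a 2.0-fold lower number from compound 1 to compound 3 (0.30 log units; within the scatter), so the two groups cannot be told apart here when each is carried on a 2-substituted ring. Nothing available explains either step.

The compounds shown leave open how 4-(trifluoromethyl)phenyl would compare, so the contributions of the group and its place to the first step cannot be separated. They also leave open whether a plain phenyl ring, or a 2-substituted ring bearing a chlorine atom, a methoxy group or an amine, would match these two compounds, and what a shorter chain would do.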